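From Trimethylphenyl to Tribromophenyl: An Expected Step

The source may report more compounds than this note shows. Statements on the series, on what has been measured and on what is new or still open speak of the compounds shown alone.

For the measured compounds named here, in an ADME assay on MT4 cells (Homo sapiens) for inhibition, read by MTT assay, with a stated time of 5 days (a lower number here means that less compound is tolerated, a higher number that more compound is tolerated), compound 1 (`Cc1cc(C)c(Oc2cc(Nc3ccc(C#N)cc3)ncc2[N+](=O)[O-])c(C)c1`) gives 69900 nM, the lower of the two numbers so far, while compound 2 (`COc1cccc(OC)c1Oc1cc(Nc2ccc(C#N)cc2)ncc1[N+](=O)[O-]`) gives 319000 nM. Compound 3 (`N#Cc1ccc(Nc2cc(Oc3c(Br)cc(Br)cc3Br)c([N+](=O)[O-])cn2)cc1`) has not yet been measured. It carries 2,4,6-tribromophenyl in place of 2,4,6-trimethylphenyl on an oxygen on an aromatic ring. Going by the values given here, no measured pair isolates this exchange, so no step beyond the scatter is expected in this assay, and neither direction is favoured. The expected change is a 1.2-fold lower number from compound 1 to compound 3 (0.07 log units; within the scatter). The estimated value for compound 3 is 60000 nM, with an expected range from 15000 nM to 250000 nM.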

Compound 3, half-maximal cytotoxic concentration: 7490 nM
For compound 3 the middle estimate is 8.0-fold (0.90 log units) above the measured one, and the stated range ends above it.
By their numbers in this assay, from the lowest: compound 3; then compound 1; then compound 2.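

In this assay, for the compounds shown here, the exchange of 2,4,6-trimethylphenyl for 2,4,6-tribromophenyl on an oxygen on an aromatic ring gives the first readable step at this position (a 9.3-fold lower number from compound 1 to compound 3 (0.97 log units; beyond the scatter)), so the number responds to what is carried here. The two groups have the same count of heavy atoms and the same ring of carbon, and differ in three bromine atoms in place of three carbon atoms. Nothing measured accounts for this step.

The compounds shown leave open whether 2,4,6-trichlorophenyl would follow the tribromophenyl group, and whether a single bromine atom on the ring would be enough.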